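A few compounds are considered here, and "the series" means these few. Any claim that something is new, unique, unknown or untested is made for them only; others in the source may bear on it.

Compound 1 `CC(=O)N1CC(CC(=O)NO)(NS(=O)(=O)c2ccc(OCc3cc(C)nc4ccccc34)cc2)C1` gives 800000 nM
Compound 2 `Cc1cc(COc2ccc(S(=O)(=O)NC3(CC(=O)NO)CN(C(=O)CC(C)C)C3)cc2)c2ccccc2n1` gives 900000 nM
Compound 3 `CCCCN1CC(CC(=O)NO)(NS(=O)(=O)c2ccc(OCc3cc(C)nc4ccccc34)cc2)C1` gives 4900000 nM

These three values come from a physicochemical assay for solubility, with a stated time of 24 h, tested at 30 mg/mL (a lower number here means a less soluble compound, a higher number a more soluble compound), and compound 3 stands highest of the three. Compound 4 `Cc1cc(COc2ccc(S(=O)(=O)NC3(CC(=O)NO)CN(CCC(F)(F)F)C3)cc2)c2ccccc2n1` has not yet been measured. The change is trifluoromethyl in place of ethyl on a saturated chain carbon, two bonds along the chain from an amine nitrogen in a ring and in words it is trifluoromethyl in place of ethyl on a saturated chain carbon, two bonds along the chain from an amine nitrogen in a ring. Cut one bond further out, the same difference reads butyl to 3,3,3-trifluoropropyl.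

Two measured steps change the group on that same nitrogen. One is a 6.1-fold higher number from compound 1 to compound 3 (0.79 log units; beyond the scatter) and the other is a 5.4-fold higher number from compound 2 to compound 3 (0.74 log units; beyond the scatter) and each puts butyl where a carbonyl group stood. A third step is a 1.1-fold higher number from compound 1 to compound 2 (0.05 log units; within the scatter) and in it the nitrogen keeps its carbonyl. Going by the values given here, no measured compound carries fluorine, so the data hold no direct measure of this change.

With compound 3 at 4900000 nM as the top value, a modest fall is expected rather than a further rise, and it should be no larger than the two steps at that nitrogen. The estimate is a 2.5-fold lower number from compound 3 to compound 4 (0.39 log units; beyond the scatter) for this step. Compound 4 is estimated at 2000000 nM with an expected range of 700000 nM to 5000000 nM on this reading.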

Compound 4, solubility: 3400000 nM
Estimate against measurement, compound 4: 1.7-fold (0.23 log units) below, and the stated range covers the measured number.
By their numbers in this assay, from the lowest: compounds 1 and 2 (each within the scatter of the next); then compounds 4 and 3 (each within the scatter of the next).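

In this assay, putting trifluoromethyl in place of the ethyl end of the butyl group gives a 1.4-fold lower number from compound 3 to compound 4 (0.16 log units; within the scatter) and so, although compound 4 is the only compound shown that carries fluorine, its number cannot be told apart from that of compound 3 at this position on the chain. The other two new steps, a 3.8-fold higher number from compound 2 to compound 4 (0.58 log units; beyond the scatter) and a 4.3-fold higher number from compound 1 to compound 4 (0.63 log units; beyond the scatter) on the ring nitrogen, are both beyond the scatter and point the same way as the earlier steps to butyl, so the four compounds now fall into two groups: compound 1 and compound 2 with a carbonyl on that nitrogen, and compound 3 and compound 4 with a plain or fluorinated chain, and no compound shown goes against this split. Nothing among the data shown gives a cause for either the split or the near match of compound 3 and compound 4.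

The compounds shown leave open whether the split holds for other groups on the ring nitrogen, such as a chain ending in an amine or a carboxylic acid. They also leave open how a longer chain, or a shorter one such as 2,2,2-trifluoroethyl, would compare with butyl and 3,3,3-trifluoropropyl.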